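Side-chain amides: from compound 3 to compound 4

The source may report more compounds than this note shows. Statements on the series, on what has been measured and on what is new or still open speak of the compounds shown alone.

Measured in a functional assay on U-937 cells (Homo sapiens) for antiproliferative activity, read by MTT assay, with a stated time of 24 h (a lower number here means a stronger inhibitor, a higher number a weaker inhibitor), on the shared core:
Compound 1 `CCCCc1oc2ccccc2c1C(=O)c1ccc(OCC(N)=O)cc1` gives 42200 nM
Compound 2 `CCCCc1oc2ccccc2c1C(=O)c1ccc(OCC(=O)NCc2ccccc2)cc1` gives 16300 nM
Compound 3 `CCCCc1oc2ccccc2c1C(=O)c1ccc(OCC(=O)N[C@H](C)c2ccccc2)cc1` gives 19800 nM

Compound 3 cannot be separated from compound 2, with a 1.2-fold higher number from compound 2 to compound 3 (0.08 log units; within the scatter) as the gap. Both sit under compound 1 by steps beyond the scatter. Compound 4 `CCCCc1oc2ccccc2c1C(=O)c1ccc(OCCCC(=O)N2CCOCC2)cc1` comes from compound 3 by a single exchange (2-((morpholin-4-yl)carbonyl)ethyl in place of (1-phenylethyl)carbamoyl on a saturated chain carbon bound to an oxygen on an aromatic ring). Within the data shown here, no measured step covers this exchange directly. Only a 2.6-fold lower number from compound 1 to compound 2 (0.41 log units; beyond the scatter) and a 2.1-fold lower number from compound 1 to compound 3 (0.33 log units; beyond the scatter) bear on it: both are modest, and in both the number fell as benzyl or 1-phenylethyl entered on the amide-type nitrogen. Here the 1-phenylethyl group leaves, and the entering 2-((morpholin-4-yl)carbonyl)ethyl holds no aromatic ring. In this assay a small upward step towards compound 1 is therefore expected, possibly inside the scatter. The expected change is a 1.5-fold higher number from compound 3 to compound 4 (0.18 log units; within the scatter) with wide uncertainty. Compound 4 is estimated at 30000 nM (expected range 14000 nM to 65000 nM).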

Compound 4, half-maximal inhibitory concentration: 21400 nM
For compound 4 the middle estimate is 1.4-fold (0.15 log units) above the measured one, within the range that was stated.
By their numbers in this assay, from the lowest: compounds 2, 3, 4 and 1 (each within the scatter of the next, the first and the last beyond it).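

In this assay the exchange on the saturated chain carbon bound to an oxygen on an aromatic ring gives a 1.1-fold higher number from compound 3 to compound 4 (0.03 log units; within the scatter) and a 1.3-fold higher number from compound 2 to compound 4 (0.12 log units; within the scatter) so a side chain with no aromatic ring and no hydrogen-bond donor cannot be told apart from the two aromatic amides at this place. The step of a 2.0-fold lower number from compound 1 to compound 4 (0.29 log units; within the scatter) also stays within the scatter, so compound 4 cannot be told apart from the plain carbamoyl compound either, and it does not fix where this group belongs in the narrow span of the set. No evidence bears on why these numbers stay together.

The ethyl link and the morpholin-4-yl carbonyl enter together in compound 4, so their separate contributions stay unresolved. Also open, as far as these compounds go, is whether a side chain ending in a carboxylic acid or a primary amine would move the number beyond the scatter.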